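The source may hold more compounds than are shown below. What is called first, only, known or untested is meant among the compounds shown, and "the series" means these compounds.

Measured in a functional assay on DU-145 cells (Homo sapiens) for inhibition, read by MTT assay, with a stated time of 72 h; on this read-out lower numbers stand for stronger inhibition and higher numbers for weaker inhibition:
- compound 1 `O=C1C=C(N2CCN(c3ccc(Cl)cc3)CC2)C(=O)c2ccccc21`: 29500 nM
- compound 2 `O=C1C=C(N2CCN(c3ccc(Br)cc3)CC2)C(=O)c2ccccc21`: > 50000 nM, which is a limit of the assay and not a number
- compound 3 `O=C1C=C(N2CCN(c3cccc(Cl)c3)CC2)C(=O)c2ccccc21`: 8300 nM

Of these three, compound 3 stands lowest, and both of its gaps lie beyond the scatter: a 3.6-fold lower number from compound 1 to compound 3 (0.55 log units; beyond the scatter), and an at least 6.0-fold lower number from compound 2 to compound 3 (0.77 log units; beyond the scatter).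

The next compound, compound 4 `Cc1ccccc1N1CCN(C2=CC(=O)c3ccccc3C2=O)CC1`, carries 2-methylphenyl in place of 3-chlorophenyl on an amine nitrogen in a ring.

Going by the values given here, no measured step makes this exact swap. The closest guide is the modest change seen when only the aryl group on that nitrogen was altered, a 3.6-fold lower number from compound 1 to compound 3 (0.55 log units; beyond the scatter). Exchanging bromo for chloro adds a little more: an at least 1.6-fold higher number from compound 1 to compound 2 (0.22 log units; that floor lies within the scatter). Together these show that this group can move the number, although only within a limited span.

Since compound 3 already holds the lowest value, 8300 nM, a modest rise towards weaker inhibition seems the likelier outcome in this assay. The expected step is a 2.4-fold higher number from compound 3 to compound 4 (0.38 log units; beyond the scatter). The estimated value for compound 4 is 20000 nM, with an expected range of 7000 nM to 48000 nM.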

Compound 4, half-maximal inhibitory concentration: 5700 nM
Compound 4: middle estimate off by 3.5-fold (0.55 log units), on the high side; the whole stated range lies above it.
By their numbers in this assay, from the lowest: compounds 4 and 3 (each within the scatter of the next); then compound 1. At a limit, above all of these: compound 2.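

In this assay, the change from 3-chlorophenyl to 2-methylphenyl gives a 1.5-fold lower number from compound 3 to compound 4 (0.16 log units; within the scatter), so an aryl group with no halogen at all can match the 3-chlorophenyl group on this ring nitrogen. The 4-chlorophenyl and 4-bromophenyl compounds both sit clearly apart, with a 5.2-fold lower number from compound 1 to compound 4 (0.71 log units; beyond the scatter) and an at least 8.7-fold lower number from compound 2 to compound 4 (0.94 log units; beyond the scatter). The value of compound 2 is a limit of the assay and not a number: the limit of > 50000 nM in this assay, at which 1 of the 4 values shown sits.

Compound 4 alters both the substituent and its place on the aryl ring, so the effects of these two changes cannot be told apart here. As far as these compounds go, a 2-chlorophenyl or 3-methylphenyl group would separate them, while the effect of an aryl ring carrying an amine or a carboxylic acid remains open.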